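Pyrimidin-5-yl for Pyridin-3-yl on a Shared Core

This account rests on a few compounds, and the source may have more. Where it says the series, first, only, none or still open, it means among the compounds named here.

Three measured compounds share one core and differ in the groups attached to it. Compound 1 `CO[C@@H]1CC=C2NN(c3cc(Cl)cc(Cl)c3)C(=O)C[C@]2(C)O1`, compound 2 `CO[C@@H]1CC=C2NN(c3cccnc3)C(=O)C[C@]2(C)O1` and compound 3 `CO[C@@H]1CC=C2NN(c3cc4ccccc4[nH]3)C(=O)C[C@]2(c2ccccc2)O1` were all tested in a functional assay on SK-BR-3 cells (Homo sapiens) for inhibition, read by sulforhodamine B assay, with a stated time of 48 h; on this read-out lower numbers stand for stronger inhibition and higher numbers for weaker inhibition. Compound 1 gives 18800 nM. Compound 2 gives 15200 nM, the second highest of the three numbers; its gap to compound 1 lies within the scatter, so no order between the two can be stated. Compound 3 gives 530 nM, a much lower number, and that gap is beyond the scatter, though compound 3 differs from compound 2 in more than one place, so no single step can be read from the pair.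

Compound 4 `CO[C@@H]1CC=C2NN(c3cncnc3)C(=O)C[C@]2(C)O1` differs from compound 2 in one place only: pyrimidin-5-yl in place of pyridin-3-yl on an amide-type nitrogen in a ring. Among the compounds with values here, no measured pair shows this change, so the expectation rests on compound 2 alone. The expected step in this assay from compound 2 to compound 4 is a 1.2-fold higher number from compound 2 to compound 4 (0.07 log units; within the scatter), which is not beyond the scatter. Compound 4 is therefore estimated at 18000 nM, within a range from 7000 nM to 45000 nM.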

Compound 4, half-maximal inhibitory concentration: 3400 nM
Compound 4: middle estimate off by 5.3-fold (0.72 log units), on the high side, and the stated range ends above it.
By their numbers in this assay, from the lowest: compound 3; then compound 4; then compounds 2 and 1 (each within the scatter of the next).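

In this assay, the group on the amide-type nitrogen in a ring proves sensitive to a small change within an aromatic ring: the step is a 4.5-fold lower number from compound 2 to compound 4 (0.65 log units; beyond the scatter) and lies beyond the scatter. Both groups are six-membered aromatic rings of the same heavy-atom count, but pyrimidin-5-yl has 2 hetero atoms where pyridin-3-yl has 1, so the change in ring atoms alone is enough to shift the number, at least on this single pair with the methyl group kept in place. Nothing measured here accounts for the size or direction of this step.

From the compounds shown here alone, it remains open whether a pyridin-4-yl or pyrazin-2-yl group at this position would give a similar step. Going by these compounds, it is equally open whether the same exchange would carry over to the shared core with a phenyl group in place of the methyl group.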